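Sulfonyl aryl swap: fluoro to methyl

This account rests on a few compounds, and the source may have more. Where it says the series, first, only, none or still open, it means among the compounds named here.

Compound 3 `CC1CCN(c2c(S(=O)(=O)c3ccc(F)c(Cl)c3)cnc3ccc(F)cc23)CC1` gives 95% in an assay on isolated protein for displacement of a labelled ligand from metabotropic glutamate receptor 5 (Homo sapiens), with a stated time of 60 min, tested at 1 uM (a higher number here means more inhibition at the concentration tested (going by the name of the read-out), a lower number less inhibition), the highest of the three numbers; compound 2 `Cc1ccc(S(=O)(=O)c2cnc3ccc(Cl)cc3c2N2CCC(C)CC2)cc1Cl` gives 81% and compound 1 `CC1CCN(c2c(S(=O)(=O)c3ccc(C#N)cc3)cnc3ccc(F)cc23)CC1` gives 75%. Compound 4 `Cc1ccc(S(=O)(=O)c2cnc3ccc(F)cc3c2N2CCC(C)CC2)cc1Cl` differs from compound 3 by methyl in place of fluoro on an aromatic carbon. For the measured compounds named here, no measured step changes this position directly; the only step on the sulfonyl aryl group, a number 20 percentage points higher from compound 1 to compound 3 (beyond the scatter), concerns a different pair of groups. Compound 2 already carries the 3-chloro-4-methylphenyl group and reads below compound 3, which suggests a small drop is plausible for compound 4. The step expected is a number 8 percentage points lower from compound 3 to compound 4 (within the scatter), downward but near the scatter. Compound 4 is estimated at 87%, between 74% and 97%.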

Compound 4, a percentage reported as inhibition, at one concentration (the size of the read-out at that concentration, not a potency): 91%
Compound 4: the middle estimate sits 4 percentage points below what was measured; measured number inside the range.
By their numbers in this assay, from the lowest: compounds 1, 2, 4 and 3 (each within the scatter of the next, the first and the last beyond it).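

In this assay, a number 4 percentage points lower from compound 3 to compound 4 (within the scatter), so the 3-chloro-4-methylphenyl and 3-chloro-4-fluorophenyl groups are not told apart at this position. Fluoro in place of chloro on an aromatic carbon also gives no separable change, with a number 10 percentage points higher from compound 2 to compound 4 (within the scatter). With a number 16 percentage points higher from compound 1 to compound 4 (beyond the scatter), the 3-chloro-4-methylphenyl group, like the 3-chloro-4-fluorophenyl group, reads clear of 4-cyanophenyl.

No measurement shown gives a reason for these steps. Going by these compounds, whether a methoxy or trifluoromethyl group in place of the methyl would hold this reading remains open.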